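The compounds below may be only part of what the source reports. "The series", "measured", "known", "first", "only" and "open" are said of these compounds alone.

In an ADME assay on isolated protein for pharmacokinetics, with UDP-glucuronosyltransferase 1A9 (Homo sapiens) as the target, read by LC-MS, with a stated time of 60 min, at 37 degrees C, tested at 1 uM, in the presence of a further agent that is not named here (on this read-out lower numbers stand for a shorter-lived compound and higher numbers for a longer-lived compound), compound 2 `CC(C)(O)CC(=O)NCCSc1nonc1/C(=N/O)Nc1ccc(F)c(C(F)F)c1` gives > 3 h, which is a limit of the assay rather than a number. Compound 1 `O=C(NCCSc1nonc1/C(=N/O)Nc1ccc(F)c(C(F)F)c1)C1CS(=O)(=O)C1` sits at the same ceiling: in this assay compound 1 gives > 3 h, again a limit. Within the data shown here, the only measured step, a step that the two limits leave unreadable from compound 1 to compound 2, therefore cannot be read in size because both values rest at the limit of > 3 h in this assay, at which 2 of the 2 values shown sit. Compound 3 `N#CCC(=O)NCCSc1nonc1/C(=N/O)Nc1ccc(F)c(C(F)F)c1` differs from compound 2 by cyano in place of 1-hydroxy-1-methylethyl on a saturated chain carbon bound to a carbonyl carbon. Among the measured compounds shown here, no measured step exchanges a group at this place, so the evidence gives no direction for the change; all that the two measured compounds show is that varied groups on the carbonyl carbon both stay at the ceiling. The expected step is accordingly a number no higher from compound 2 to compound 3 (the limit leaves the size open), nothing beyond the scatter, and most likely another limit. Compound 3 is estimated at 3 h, with a range from 1.5 h to 6 h.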

Compound 3, half-life: 1.73 h
The estimate for compound 3 lay 1.7-fold (0.24 log units) above the measured number; the measured number falls inside the stated range.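

In this assay, among these compounds, compound 3 gives a number rather than a limit, the first reading at this position that falls under the ceiling of the assay. Cyano in place of 1-hydroxy-1-methylethyl gives an at least 1.7-fold lower number from compound 2 to compound 3 (0.23 log units; that floor lies within the scatter), and the smaller group on the carbonyl carbon, set against the ring-bearing group, gives an at least 1.7-fold lower number from compound 1 to compound 3 (0.23 log units; that floor lies within the scatter). Neither step can yet be called a real drop, and the step between the other two compounds cannot be read, because their values are limits and not numbers: the limit of > 3 h in this assay, at which 2 of the 3 values shown sit.

Going by these compounds, it stays open whether the nitrile itself or the shorter group goes with the lower reading, which a longer chain ending in a nitrile could help separate. An amine or a carboxylic acid on the same saturated chain carbon would show whether other groups also fall under the ceiling.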